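Swapping a Carbamate Tail for a Difluorophenyl Amide

The source may hold more compounds than are shown below. What is called first, only, known or untested is meant among the compounds shown, and "the series" means these compounds.

Four compounds share one core and are compared in an ADME assay on Vero cells (Chlorocebus sabaeus) for cytotoxicity, read by resazurin assay, with a stated time of 3 days; a higher number here means a weaker inhibitor, a lower number a stronger inhibitor. Compound 1 is `CCOCCOC(=O)Nc1cc2nc(C3CCCCC3)[nH]c2cc1N(C)C`. In this assay compound 1 gives only a limit, > 100 ug/mL. Compound 2 is `CN(C)c1cc2[nH]c(C3CCCCC3)nc2cc1NC(=O)c1ccc(F)cc1F`. In this assay compound 2 also gives only a limit, > 100 ug/mL. Compound 3 is `CCOCCOC(=O)Nc1cc2nc(C3CCCCC3)[nH]c2cc1N(CC)CC`. In this assay compound 3 likewise gives only a limit, > 100 ug/mL.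

Compound 2 differs from compound 1 by 2,4-difluorophenyl in place of 2-ethoxyethoxy on a carbonyl carbon. The corresponding step, a step that the two limits leave unreadable from compound 1 to compound 2, cannot be sized, since the limit of > 100 ug/mL in this assay, at which 3 of the 3 values shown sit, holds both ends of it. Compound 3 differs from compound 1 by diethylamino in place of dimethylamino on an aromatic carbon; this is how the two cores differ, and the step that the two limits leave unreadable from compound 1 to compound 3 is equally unreadable.

Compound 4, still unmeasured, is `CCN(CC)c1cc2[nH]c(C3CCCCC3)nc2cc1NC(=O)c1ccc(F)cc1F`. It differs from compound 3 by 2,4-difluorophenyl in place of 2-ethoxyethoxy on a carbonyl carbon, the same change that turned compound 1 into compound 2, made on the other core. Across the three measured compounds nothing has yet moved below the limit, so the step of a number no higher from compound 3 to compound 4 (the limit leaves the size open) is expected to be negligible. Compound 4 is therefore estimated at 100 ug/mL, most likely reported again only as a limit.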

Compound 4, half-maximal inhibitory concentration: > 100 ug/mL
Compound 4: no number, only a limit; the forecaster's own chance of this, stated with the estimate: 85%; the middle value lies on the limit itself.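

In this assay compound 4 gives only a limit, > 100 ug/mL. Neither the step from compound 3 to compound 4 nor the step from compound 2 to compound 4 can be read, because every value rests on the same limit: the limit of > 100 ug/mL in this assay, at which 4 of the 4 values shown sit.

The compounds shown leave open whether either change alters the result at all, and how far any of the four compounds lies from that limit.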